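A few compounds are considered here, and "the series" means these few. Any claim that something is new, unique, unknown or untested is made for them only; others in the source may bear on it.

Measured so far:
Compound 1, `O=C(/C=C/c1ccc2c(c1)B(O)OC2)c1ccc(I)cc1`: 4200 nM in a functional assay on SK-OV-3 cells (Homo sapiens) for cytotoxicity, read by MTT assay, with a stated time of 48 h; on this read-out higher numbers stand for weaker inhibition and lower numbers for stronger inhibition
Compound 2, `O=C(/C=C/c1ccc2c(c1)B(O)OC2)c1ccccc1O`: 48800 nM

Within the data shown here, compound 2 gives the highest of the two numbers in this assay; the only measured step, a 12-fold higher number from compound 1 to compound 2 (1.07 log units; beyond the scatter), lies beyond the scatter and sets compound 2 well apart from compound 1.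

Compound 3, `O=C(/C=C/c1ccc2c(c1)B(O)OC2)c1cccc(O)c1`, is compound 2 with 3-hydroxyphenyl in place of 2-hydroxyphenyl on a carbonyl carbon. Among the measured compounds shown here, no measured pair differs only in 3-hydroxyphenyl against 2-hydroxyphenyl, so nothing bears directly on this change. The one step shown, a 12-fold higher number from compound 1 to compound 2 (1.07 log units; beyond the scatter), exchanges the whole aryl group on the carbonyl carbon and tells only that this part of the series can shift the number strongly. With compound 2 standing at the top, a move back toward compound 1 is judged somewhat more likely than a further rise, but the direction is not secured. For compound 3 the expected step is a 2.0-fold lower number from compound 2 to compound 3 (0.29 log units; within the scatter). Compound 3 is therefore estimated at 25000 nM, between 8000 nM and 80000 nM.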

Compound 3, half-maximal inhibitory concentration: 3800 nM
Beside the measured number, compound 3's estimate is 6.6-fold (0.82 log units) above it, outside the stated range (below it).
By their numbers in this assay, from the lowest: compounds 3 and 1 (each within the scatter of the next); then compound 2.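

In this assay, moving the hydroxyl within the hydroxyphenyl group on the carbonyl carbon gives a 13-fold lower number from compound 2 to compound 3 (1.11 log units; beyond the scatter) and so, with the same atoms joined differently, this change alone shifts the number beyond the scatter. Exchange of 4-iodophenyl for 3-hydroxyphenyl gives a 1.1-fold lower number from compound 1 to compound 3 (0.04 log units; within the scatter) and separates those two compounds by no more than the scatter, so the high number of compound 2 goes with 2-hydroxyphenyl and not with hydroxyphenyl groups in general. No data here account for the gap between the two hydroxyphenyl groups.

Open, from the compounds shown here alone, is where 4-hydroxyphenyl would stand on the carbonyl carbon. Also open, going by these compounds, is whether the high number needs the hydroxyl itself, which 2-methoxyphenyl or 2-aminophenyl in the same place would test.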